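From Hydroxy to Fluoro on Compound 2

This account rests on a few compounds, and the source may have more. Where it says the series, first, only, none or still open, it means among the compounds named here.

Three related compounds have been tested in a functional assay on BGC-823 cells (Homo sapiens) for cytotoxicity, read by MTT assay, with a stated time of 48 h; on this read-out lower numbers stand for stronger inhibition and higher numbers for weaker inhibition. Compound 1 (`NNC(=O)CSc1nnc(-c2ccncc2)o1`) gives 3260 nM, compound 2 (`O=C(CSc1nnc(-c2ccncc2)o1)N/N=C/c1ccc(O)cc1`) gives 7940 nM, and compound 3 (`O=C(CSc1nnc(-c2ccncc2)o1)N/N=C/c1cccc(C(F)(F)F)c1`) gives 13000 nM. Compound 2 therefore lies within the usual scatter of compound 3, so those two cannot be told apart. Its number is higher than that of compound 1 by more than the scatter, which means weaker inhibition.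

Compound 4 (`O=C(CSc1nnc(-c2ccncc2)o1)N/N=C/c1ccccc1F`) has not yet been measured. It differs from compound 2 in one place: 2-fluorophenyl in place of 4-hydroxyphenyl on a carbon with a double bond to nitrogen. Here, 2-fluorophenyl stands in place of 4-hydroxyphenyl on a carbon with a double bond to nitrogen.

Within the data shown here, no measured pair isolates this change, so only a loose comparison is available. Compound 3 also carries a different group at this place, and its value of 13000 nM stays within the scatter of compound 2. No change beyond the scatter is therefore expected in this assay, and the estimated step of a 1.1-fold higher number from compound 2 to compound 4 (0.05 log units; within the scatter) leans only slightly toward weaker inhibition. For compound 4 the estimated value is 9000 nM, with an expected range from 3500 nM to 23000 nM.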

Compound 4, half-maximal inhibitory concentration: 24000 nM
Estimate against measurement, compound 4: 2.7-fold (0.43 log units) below; measured number outside the range, above it.
By their numbers in this assay, from the lowest: compound 1; then compounds 2, 3 and 4 (each within the scatter of the next, the first and the last beyond it).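

In this assay, the place on the carbon with a double bond to nitrogen proves sensitive to its group: a 3.0-fold higher number from compound 2 to compound 4 (0.48 log units; beyond the scatter) is a modest rise, but it lies beyond the scatter, which the earlier comparison of compound 2 with compound 3 did not. Both groups in this change are six-membered aromatic rings of the same heavy-atom count, so the ring is kept while the hydroxy group gives way to fluorine, and the hydrogen-bond donor and acceptor counted on 4-hydroxyphenyl are lost. Nothing measured here explains the weaker inhibition.

The compounds shown leave open whether the rise follows the loss of the hydroxy group, the arrival of fluorine, or the different ring position of each. Also open, going by these compounds, is how 4-fluorophenyl, 2-hydroxyphenyl or 4-aminophenyl would behave at this place.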